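Fluoro for Methyl on the Aryl Ring of Compound 1

The compounds below may be only part of what the source reports. "The series", "measured", "known", "first", "only" and "open" are said of these compounds alone.

Compound 1 `Cc1ccc(-c2nnc(SCCn3c([N+](=O)[O-])cnc3C)o2)cc1`: 2200 nM
Compound 2 `COc1ccc(-c2nnc(SCCn3c([N+](=O)[O-])cnc3C)o2)cc1`: 5800 nM

In a functional assay on HepG2 cells (Homo sapiens) for cytotoxicity, read by MTT assay, with a stated time of 48 h (a higher number here means a weaker inhibitor, a lower number a stronger inhibitor), compound 1 gives 2200 nM, the lowest of the two numbers; its nearest neighbour is compound 2, whose value in this assay is 5800 nM. Within the data shown here, the one measured step, a 2.6-fold higher number from compound 1 to compound 2 (0.42 log units; beyond the scatter), changes the same aromatic carbon but with a different group. Compound 3 `Cc1ncc([N+](=O)[O-])n1CCSc1nnc(-c2ccc(F)cc2)o1` carries the change (fluoro in place of methyl on an aromatic carbon). Among the measured compounds shown here, no measured step covers fluoro directly, so only a small step, if any beyond the scatter, is expected, a 1.4-fold higher number from compound 1 to compound 3 (0.13 log units; within the scatter). Compound 3 is estimated at 3000 nM, in the range 1200 nM to 7500 nM.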

Compound 3, half-maximal inhibitory concentration: 600 nM
Beside the measured number, compound 3's estimate is 5.0-fold (0.70 log units) above it; the whole stated range lies above it.
By their numbers in this assay, from the lowest: compound 3; then compound 1; then compound 2.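

In this assay, on this aromatic carbon para to a large group, the change gives a 3.7-fold lower number from compound 1 to compound 3 (0.56 log units; beyond the scatter) and a 9.7-fold lower number from compound 2 to compound 3 (0.99 log units; beyond the scatter) as the measured steps to fluoro. Unlike the step to methoxy, replacing methyl can therefore lower the number, so the direction of change at this carbon depends on the group that enters. Nothing at hand accounts for this order of fluoro, methyl and methoxy. On these data alone, whether chloro or an amine at this carbon would give a number near that of compound 3 remains open. So does whether the same order would hold outside this cytotoxicity read-out on one cell line.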